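Taking the other hydroxy from compound 1

The source may hold more compounds than are shown below. What is called first, only, known or untested is meant among the compounds shown, and "the series" means these compounds.

Among the compounds with values here, in a functional assay on cells (Homo sapiens) for cytotoxicity, read by MTT assay, with a stated time of 48 h (on this read-out lower numbers stand for stronger inhibition and higher numbers for weaker inhibition), compound 1 `CN(CC(=O)Nc1cc(O)ccc1O)c1ccccc1` gives 6000 nM, the only true number available so far. Compound 2 `CN(CC(=O)Nc1ccccc1O)c1ccccc1` gives > 100000 nM in this assay, and this is a limit of the assay, not a number. Within the data shown here, the single measured step is therefore an at least 16-fold higher number from compound 1 to compound 2 (1.22 log units; beyond the scatter), a large one, and it rests on (the limit of > 100000 nM in this assay, at which 1 of the 2 values shown sits).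

Compound 3 `CN(CC(=O)Nc1cccc(O)c1)c1ccccc1` has not yet been measured. It differs from compound 1 as follows: hydrogen in place of hydroxy on an aromatic carbon. Among the measured compounds shown here, the hydroxy that compound 2 keeps is thus the one that compound 3 loses, on an aromatic carbon ortho to a large group and para to a hydroxy group.

The change is of the same kind, but at a different place, so the step to compound 2 is only a rough guide. Given an at least 16-fold higher number from compound 1 to compound 2 (1.22 log units; beyond the scatter), a large step toward weaker inhibition is expected in this assay. The expected change is an 8.3-fold higher number from compound 1 to compound 3 (0.92 log units; beyond the scatter). For compound 3 the estimated value is 50000 nM, within an expected range from 12000 nM to 200000 nM.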

Compound 3, half-maximal inhibitory concentration: > 100000 nM
Compound 3 was reported as a limit (the forecaster's own chance of this, stated with the estimate: 50%); middle value at least 2.0-fold (0.30 log units) away from the limit.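

Hydrogen in place of hydroxy on an aromatic carbon, here ortho to a large group and para to a hydroxy group, gives an at least 16-fold higher number from compound 1 to compound 3 (1.22 log units; beyond the scatter) in this assay. Within the data shown here, earlier, only one of the two hydroxy groups of compound 1 had been seen to matter in this way; now the loss of either one is accompanied by a large step toward weaker inhibition, and compound 1, which carries both, is the only compound of the three with a true number. The value of compound 3 is a limit and not a number, so this step has a lower bound but no exact size, and compound 2 and compound 3 cannot be placed in order: the limit of > 100000 nM in this assay, at which 2 of the 3 values shown sit.

The compounds shown leave open whether either hydroxy group can be replaced by anything other than hydrogen, such as a methoxy group or an amine, with activity kept. They also leave open how the rest of the core of compound 1 contributes, for instance whether a longer chain in place of its methyl group would change the number in this assay.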